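The source may report more compounds than this note shows. Statements on the series, on what has been measured and on what is new or still open speak of the compounds shown alone.

The compounds in this set share one core, first seen in compound 1 `CN1CCN(c2ccc(Nc3ncc4nc(Nc5ccc(F)cc5)n([C@H]5CCNC5)c4n3)cc2)CC1`, for which a functional assay on NCI-H1975 cells (Homo sapiens) for antiproliferative activity, read by MTT assay, with a stated time of 72 h (on this read-out higher numbers stand for weaker inhibition and lower numbers for stronger inhibition), reports "not determined" (no result reported). Compound 2 `CN1CCN(c2ccc(Nc3ncc4nc(Nc5ccc(F)cc5)n([C@H]5CCCN(S(=O)(=O)C6CC6)C5)c4n3)cc2)CC1` also carries a piperidin-3-yl group on the aromatic nitrogen of the shared core; in this assay compound 2 gives 1150 nM. Compound 3 `CNC(=O)CN1CC[C@H](n2c(Nc3ccc(F)cc3)nc3cnc(Nc4ccc(N5CCN(C)CC5)cc4)nc32)C1` carries the 1-((methylcarbamoyl)methyl)pyrrolidin-3-yl group on that aromatic nitrogen, and for compound 3 this assay again reports "not determined" (no result reported), so compound 3 stands alongside compound 1 as a compound without a single result in this assay. Compound 4 `CN1CCN(c2ccc(Nc3ncc4nc(Nc5ccc(F)cc5)n([C@H]5CCCN(C(=O)CO)C5)c4n3)cc2)CC1` differs from compound 3 in one place: 1-((hydroxymethyl)carbonyl)piperidin-3-yl in place of 1-((methylcarbamoyl)methyl)pyrrolidin-3-yl on an aromatic nitrogen. Within the data shown here, no step between measured compounds involves compound 3 or compound 4, so neither the size nor the direction of the change in this assay can be read from what has been measured; whether the step lies beyond the scatter remains open. The only point of reference is compound 2, which shares the piperidin-3-yl group on the aromatic nitrogen and whose 1150 nM offers a rough anchor. Compound 4 is therefore expected to fall in a similar region, with an estimate of 800 nM and a range from 200 nM to 3500 nM.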

Compound 4, half-maximal inhibitory concentration: 750 nM
Compound 4: middle estimate off by 1.1-fold (0.03 log units), on the high side, and the stated range covers the measured number.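

Among these compounds, the step of a 1.5-fold lower number from compound 2 to compound 4 (0.19 log units; within the scatter) in this assay gives the first readable comparison at this position, the amine nitrogen in the piperidin-3-yl ring on the aromatic nitrogen of the shared core. With that ring held constant, a cyclopropylsulfonyl group and a (hydroxymethyl)carbonyl group cannot be told apart on this read-out, so two quite different groups on the ring nitrogen fall within the scatter of each other, although this rests on a single pair and sets no wider pattern. No measurement at hand explains this result or bears on any property of either group.

Steps to compound 1 and compound 3 cannot be read, as neither has a single number in this assay, so the effect of the pyrrolidin-3-yl ring against the piperidin-3-yl ring, and of the 1-((methylcarbamoyl)methyl) side chain, stays unresolved. From the compounds shown here alone, it also remains open whether this tolerance would extend to a free amine, a carboxylic acid or a longer chain on the piperidine nitrogen, since the two values shown cover only a sulfonyl and a carbonyl attachment.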